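The source may hold more compounds than are shown below. What is called first, only, known or untested is meant among the compounds shown, and "the series" means these compounds.

The measured compounds:
Compound 1, `CNC(=O)c1cc(Oc2ccc(NC(=O)c3nccc(-c4ccc(OC)cc4)n3)cc2)ccn1`, gives 11100 nM in a functional assay on A549 cells (Homo sapiens) for cytotoxicity, read by MTT assay, with a stated time of 72 h; a lower number here means a stronger inhibitor, a higher number a weaker inhibitor.
Compound 2, `CNC(=O)c1cc(Oc2ccc(NC(=O)c3nccc(-c4ccc(OC)cc4)n3)cc2F)ccn1`, gives 16600 nM in this assay.
Compound 3, `CNC(=O)c1cc(Oc2ccc(NC(=O)c3cc(-c4ccc(C)cc4)ncn3)cc2F)ccn1`, gives 13200 nM in this assay.

Among these three, compound 1 holds the lowest number, but its gaps to compound 2 and to compound 3 both fall within the scatter, so no ranking can be drawn from them. Within the data shown here, the only measured single-point step, a 1.5-fold higher number from compound 1 to compound 2 (0.17 log units; within the scatter), is within the scatter and concerns a different change. Compound 4, `CNC(=O)c1cc(Oc2ccc(NC(=O)c3nccc(-c4ccc([N+](=O)[O-])cc4)n3)cc2)ccn1`, differs from compound 1 by nitro in place of methoxy on an aromatic carbon. Among the measured compounds shown here, no measured step touches this change, so nothing in the data points in either direction. A step within the scatter is therefore expected, a 1.1-fold higher number from compound 1 to compound 4 (0.03 log units; within the scatter). Compound 4 is estimated at 12000 nM, with a range from 5000 nM to 30000 nM.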

Compound 4, half-maximal inhibitory concentration: > 100000 nM
Compound 4: no number, only a limit; the forecaster's own chance of this, stated with the estimate: 10%; middle value at least 8.3-fold (0.92 log units) from the limit.
By their numbers in this assay, from the lowest: compounds 1, 3 and 2 (each within the scatter of the next). At a limit, above all of these: compound 4.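

Replacing 4-methoxyphenyl with 4-nitrophenyl produces the only step beyond the scatter shown in this assay: an at least 9.0-fold higher number from compound 1 to compound 4 (0.95 log units; beyond the scatter). Among these compounds, this shows that the aromatic carbon para to a large group can respond to a change, which the earlier steps and values did not reveal. Compound 4 has a limit of the assay rather than a number: the limit of > 100000 nM in this assay, at which 1 of the 4 values shown sits.

On these data alone, how far compound 4 lies beyond that limit stays open. Also open, as far as these compounds go, is whether an amine, a nitrile or a chloro group on that carbon would read like compound 1 or like compound 4.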